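This account rests on a few compounds, and the source may have more. Where it says the series, first, only, none or still open, it means among the compounds named here.

Series notes, following the step from compound 2 to compound 3. Compound 1 `CN1C(=S)[C@@H](NC(=O)c2nc(Cc3ccccc3)n(C)n2)COc2ccccc21` carries a hydrogen on the saturated chain carbon bound to an aromatic nitrogen. In a toxicity assay on HT-29 cells (Homo sapiens) for cytotoxicity (a lower number here means that less compound is tolerated, a higher number that more compound is tolerated), compound 1 gives > 100000 nM, a limit of the assay rather than a number. Compound 2 `CN1C(=S)[C@@H](NC(=O)c2nc(Cc3ccccc3)n(CCC(F)(F)F)n2)COc2ccccc21` carries the 2,2,2-trifluoroethyl group at that place. In this assay compound 2 gives > 100000 nM, again a limit and not a number. The step that the two limits leave unreadable from compound 1 to compound 2 therefore has no readable size, because both of its ends sit at the limit of > 100000 nM in this assay, at which 2 of the 2 values shown sit. For the measured compounds named here, compound 2 thus stands at the limit, as does the one other value shown for the series. Compound 3 `CN1C(=S)[C@@H](NC(=O)c2nc(Cc3ccccc3)n(CC3CCOCC3)n2)COc2ccccc21` is not yet measured; it differs from compound 2 by oxan-4-yl in place of 2,2,2-trifluoroethyl on a saturated chain carbon bound to an aromatic nitrogen. Going by the values given here, the only measured step, a step that the two limits leave unreadable from compound 1 to compound 2, concerns the same place on the core but carries no readable size, so the record gives no direction and no magnitude for the change in this assay. The expectation is that compound 3 stays at the limit, with an expected step of a number no higher from compound 2 to compound 3 (the limit leaves the size open) of no readable size. Compound 3 is estimated at 100000 nM, with a range from 40000 nM to 400000 nM.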

Compound 3, half-maximal cytotoxic concentration: > 100000 nM
Compound 3: no number, only a limit (the forecaster's own chance of this, stated with the estimate: 85%); the middle value sits exactly at the limit.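

In this assay compound 3 gives > 100000 nM as a limit of the assay, not a number. For the compounds shown here, no step among compound 1, compound 2 and compound 3 can be read, because all three values sit at one limit: the limit of > 100000 nM in this assay, at which 3 of the 3 values shown sit.

The compounds shown leave open how much of each compound is tolerated and whether any group at this place changes that.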